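Carbonyl substituent exchange on the shared core: working notes

The source may hold more compounds than are shown below. What is called first, only, known or untested is meant among the compounds shown, and "the series" means these compounds.

In a functional assay on MCF7 cells (Homo sapiens), read by MTT assay, with a stated time of 48 h (on this read-out higher numbers stand for weaker inhibition and lower numbers for stronger inhibition), compound 1 (`CCn1c(C(=O)NCCN(C)C)ccc1C(CC)(CC)c1ccc(OCC(O)C(C)(C)C)c(C)c1`) gives 660 nM and compound 2 (`CCn1c(C(=O)N(CCC#N)CCC#N)ccc1C(CC)(CC)c1ccc(OCC(O)C(C)(C)C)c(C)c1`) gives 480 nM. For the measured compounds named here, these are the only two numbers so far, and they do not separate, so compound 2 stands level with compound 1.

Compound 3 (`C#CC(C)OC(=O)c1ccc(C(CC)(CC)c2ccc(OCC(O)C(C)(C)C)c(C)c2)n1CC`) has not been measured. Its difference from compound 2 is a group of 5 heavy atoms (4 carbon, 1 oxygen; no ring) in place of a group of 9 heavy atoms (6 carbon, 3 nitrogen; no ring), on a carbonyl carbon. The entering group is (1-methylprop-2-yn-1-yl)oxy, on a carbonyl carbon whose other neighbours are: aromatic carbon.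

Going by the values given here, one measured step bears on this change: a 1.4-fold lower number from compound 1 to compound 2 (0.14 log units; within the scatter). It exchanges one nitrogen-containing group for another on the same carbonyl carbon. Among the compounds with values here, no measured compound carries the entering group, so this evidence is indirect and the range has to stay wide. On the guide of a 1.4-fold lower number from compound 1 to compound 2 (0.14 log units; within the scatter), no step beyond the scatter is expected in this assay, in either direction.

The expected step is a 1.1-fold higher number from compound 2 to compound 3 (0.06 log units; within the scatter).

Compound 3 is estimated at 550 nM, with an expected range of 170 nM to 1800 nM.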

Compound 3, half-maximal inhibitory concentration: > 50000 nM
Compound 3 was reported as a limit; the forecaster's own chance of this, stated with the estimate: 5%; at least 90-fold (1.95 log units) between middle value and limit.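

The group on the carbonyl carbon matters far more than the first pair suggested: (1-methylprop-2-yn-1-yl)oxy gives an at least 100-fold higher number from compound 2 to compound 3 (2.01 log units; beyond the scatter), and in place of (2-(dimethylamino)ethyl)amino it gives an at least 75-fold higher number from compound 1 to compound 3 (1.87 log units; beyond the scatter). In this assay compound 3 gives > 50000 nM, which is a limit and not a number. This position can therefore separate compounds in this assay, though the exchange among the two nitrogen-containing groups did not show it, and the full size of the new steps stays unknown because compound 3 reads only as a limit: the limit of > 50000 nM in this assay, at which 1 of the 3 values shown sits.

The compounds shown leave open whether the loss goes with the oxygen attached to the carbonyl carbon, with the triple bond of the entering group, or with its branching methyl, since the entering group brings these together. A plain ethoxy group, a free carboxylic acid, or a simple amine bearing the same 1-methylprop-2-yn-1-yl chain on this carbonyl carbon would bear on that question, and none of these is among the compounds shown.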